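Amine Tail Variation on the Propoxy Chain of Compound 1

The source may hold more compounds than are shown below. What is called first, only, known or untested is meant among the compounds shown, and "the series" means these compounds.

For the measured compounds named here, in a functional assay on K562 cells (Homo sapiens) for inhibition, read by MTT assay and WST assay, with a stated time of 72 h, tested at 10 uM (on this read-out higher numbers stand for more inhibition of growth at the one concentration tested and lower numbers for less inhibition of growth), compound 1 `CCN(CC)CCCOc1cc2ncnc(Nc3ccc4sc(C(=O)Nc5c(C)cccc5Cl)cc4c3)c2cc1OC` gives 72.5%, the highest of the two numbers so far; compound 2 `Cc1nc(Nc2ccc3sc(C(=O)Nc4c(C)cccc4Cl)cc3c2)cc(N2CCN(C)CC2)n1` gives 32.4%, a gap beyond the usual scatter. Compound 3 `COc1cc2c(Nc3ccc4sc(C(=O)Nc5c(C)cccc5Cl)cc4c3)ncnc2cc1OCCCN1CCCCC1` differs from compound 1 by piperidin-1-yl in place of diethylamino on a saturated chain carbon, three bonds along the chain from an oxygen on an aromatic ring. Going by the values given here, no measured pair differs in only that place, so this step is untested. The expected change is small, with no direction favored and within the scatter, which is what the expected step of a number 2.5 percentage points lower from compound 1 to compound 3 (within the scatter) means. In this assay compound 3 is estimated at 70%, with a range from 55% to 85%.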

Compound 3, percent growth inhibition at one concentration: 71.8%
Estimate against measurement, compound 3: 1.8 percentage points below; low and high end bracket the measured number.
By their numbers in this assay, from the lowest: compound 2; then compounds 3 and 1 (each within the scatter of the next).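

Closing the diethylamino tail into piperidin-1-yl on the 3-carbon propoxy chain leaves growth inhibition in this assay essentially unmoved, a number 0.7 percentage points lower from compound 1 to compound 3 (within the scatter). For the compounds shown here, this is the first direct reading at this position, and it shows that this swap, which adds a six-membered non-aromatic ring, is tolerated here. No measurement on hand explains this tolerance.

Open, on these data alone, are other amines at the chain end, such as morpholin-4-yl or 4-methylpiperazin-1-yl, and whether a shorter 2-carbon ethoxy chain would read the same.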